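Chloro Replaces Trifluoromethyl on the Biaryl Amide Ring

The source may hold more compounds than are shown below. What is called first, only, known or untested is meant among the compounds shown, and "the series" means these compounds.

Compound 1 `CC(C)N(Cc1cccc(OCCCCCC(=O)O)c1)C(=O)c1ccc(-c2cccc(O)c2)cc1`, compound 2 `CC(C)N(Cc1cccc(OCCCCCC(=O)O)c1)C(=O)c1ccc(-c2c[nH]c3ccccc23)cc1` and compound 3 `CC(C)N(Cc1cccc(OCCCCCC(=O)O)c1)C(=O)c1ccc(-c2cccc(C(F)(F)F)c2)cc1` share one core and differ only in the group carried by the outer aromatic ring. In an ADME assay on HEK293 cells (Homo sapiens) for cytotoxicity, read by CellTiter-Glo and resazurin assay, with a stated time of 72 h (on this read-out higher numbers stand for an effect only at larger amounts of compound and lower numbers for an effect already at smaller amounts), compound 1 gives > 26000 nM, which is a limit of the assay and not a number. Compound 2 likewise reaches only the limit > 26000 nM in this assay. Compound 3 too stops at the limit > 26000 nM in this assay. Compound 3 therefore stands where every measured compound stands, namely at the limit of > 26000 nM in this assay, at which 3 of the 3 values shown sit. Accordingly the steps a step that the two limits leave unreadable from compound 1 to compound 2, a step that the two limits leave unreadable from compound 1 to compound 3 and a step that the two limits leave unreadable from compound 2 to compound 3 remain unreadable in size.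

Compound 4 `CC(C)N(Cc1cccc(OCCCCCC(=O)O)c1)C(=O)c1ccc(-c2cccc(Cl)c2)cc1` differs from compound 3 by chloro in place of trifluoromethyl on an aromatic carbon. For the measured compounds named here, the only measured change at that position, a step that the two limits leave unreadable from compound 2 to compound 3, left no readable size, so nothing argues for a step beyond the scatter in either direction. The estimated step that the limit leaves unreadable from compound 3 to compound 4 is therefore expected to be small. Compound 4 is expected to give 30000 nM in this assay, within 10000 nM to 80000 nM, most probably reported again as a limit.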

Compound 4, half-maximal effective concentration: > 21900 nM
Compound 4 gave a limit, no number (the forecaster's own chance of this, stated with the estimate: 75%); the middle value lies beyond the limit too.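

Compound 4 gives > 21900 nM in this assay, a limit and not a number, so its steps from compound 1, compound 2 and compound 3 cannot be read in size. The compounds shown leave open whether the groups compared differ at all in this assay.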